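This account rests on a few compounds, and the source may have more. Where it says the series, first, only, none or still open, it means among the compounds named here.

Measured compounds:
compound 1, `COCCOC1CCN(c2nc(N)c3cc(OC)c(OC)cc3n2)CC1`: 2.12 nM
compound 2, `CCOC(C)COC1CCN(c2nc(N)c3cc(OC)c(OC)cc3n2)CC1`: 0.99 nM

Both were tested in an assay on brain for displacement of a labelled ligand from Adrenergic receptor alpha-1 (Rattus norvegicus); on this read-out lower numbers stand for stronger inhibition and higher numbers for weaker inhibition. Compound 1 stands at the higher of the two numbers: the step of a 2.1-fold lower number from compound 1 to compound 2 (0.33 log units; beyond the scatter) leaves compound 2 with the lower one. Compound 3, `COc1cc2nc(N3CCC(OCC(O)c4ccccc4)CC3)nc(N)c2cc1OC`, has not yet been measured. It differs from compound 1 in one place: hydroxy(phenyl)methyl in place of methoxymethyl on a saturated chain carbon bound to an oxygen on a saturated carbon. Among the compounds with values here, of the measured steps, only the one from compound 1 to compound 2 concerns the same place, and it was a modest lowering, a 2.1-fold lower number from compound 1 to compound 2 (0.33 log units; beyond the scatter). That step merely enlarged the chain, whereas the present change brings in an aromatic ring and a hydroxy group; the earlier step therefore guides the expectation only loosely. A step of similar or smaller size, most likely a small lowering, is expected, a 1.4-fold lower number from compound 1 to compound 3 (0.15 log units; within the scatter). For compound 3 in this assay the estimate is 1.5 nM, within a range from 0.5 nM to 5 nM.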

Compound 3, inhibition constant: 0.15 nM
Compound 3: middle estimate off by 10-fold (1.00 log units), on the high side; the whole stated range lies above it.
By their numbers in this assay, from the lowest: compound 3; then compound 2; then compound 1.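

In this assay, this place on the chain tolerates much more than the enlargement from methoxymethyl to 1-ethoxyethyl had suggested: hydroxy(phenyl)methyl in place of methoxymethyl gives a large step (a 14-fold lower number from compound 1 to compound 3 (1.15 log units; beyond the scatter)), well beyond the modest one seen before (a 2.1-fold lower number from compound 1 to compound 2 (0.33 log units; beyond the scatter)). The same group in place of 1-ethoxyethyl still gives a further lowering (a 6.6-fold lower number from compound 2 to compound 3 (0.82 log units; beyond the scatter)), so the larger of the two ether chains does not match it. No data are at hand that explain the size of this step.

The change brings in a six-membered aromatic ring and a hydrogen-bond donor together, so the compounds shown cannot tell how much of the step belongs to each. On these data alone, a 2-phenylethyl chain without the hydroxy group, a 2-hydroxyethyl chain without the phenyl ring, or an amine in place of the hydroxy group would bear on this question, and all three remain open.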